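This account rests on a few compounds, and the source may have more. Where it says the series, first, only, none or still open, it means among the compounds named here.

Measured so far in a functional assay on SR cells (Homo sapiens) for inhibition, read by sulforhodamine B assay, with a stated time of 48 h; on this read-out lower numbers stand for stronger inhibition of growth and higher numbers for weaker inhibition of growth:
- compound 1 `Cc1cc(O)cc(-c2nn(CC#N)cc2-c2ccnc(-c3ccc(Oc4ccccc4)cc3)c2)c1`: compound 1 gives 3770 nM
- compound 2 `COc1cc(C)cc(-c2nn(CC#N)cc2-c2ccnc(-c3ccc(N(C)C)cc3)c2)c1`: compound 2 gives 461 nM

Of the two numbers, compound 2 has the lower one; compound 1 stands at a markedly higher value, and the gap between the two lies beyond the usual scatter. Compounds 1 and 2 differ in more than one place, so their two values can only be set side by side; no single structural step explains the difference.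

Compound 3 `Cc1cc(O)cc(-c2nn(CC#N)cc2-c2ccnc(-c3ccc(N(C)C)cc3)c2)c1` is still to be measured. It differs from compound 2 by one change: hydrogen in place of methyl on an oxygen on an aromatic ring. Going by the values given here, no measured pair shows this change on its own, so the size and direction of the step have to be expected rather than read off. The working expectation is a small step, if any, toward a higher number, likely not clearly beyond the scatter: from compound 2 to compound 3 the estimated step is a 1.5-fold higher number from compound 2 to compound 3 (0.18 log units; within the scatter). Compound 3 is therefore estimated at 700 nM, with a range from 250 nM to 2500 nM.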

Compound 3, concentration for 50% growth inhibition: 2640 nM
Compound 3: the middle estimate sits 3.8-fold (0.58 log units) below what was measured; the measured number lies above the stated range.
By their numbers in this assay, from the lowest: compound 2; then compounds 3 and 1 (each within the scatter of the next).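

Working notes on the series. In this assay, going by these compounds alone, the methyl on the oxygen is the first feature of the series whose removal can be read on its own, and the step is beyond the scatter: the change from 3-methoxy-5-methylphenyl to 3-hydroxy-5-methylphenyl gives a 5.7-fold higher number from compound 2 to compound 3 (0.76 log units; beyond the scatter) with dimethylamino held constant. With the 3-hydroxy-5-methylphenyl group held constant, dimethylamino in place of phenoxy gives a 1.4-fold lower number from compound 1 to compound 3 (0.15 log units; within the scatter) and stays within the scatter, so this read-out does not separate those two groups on the hydroxy compounds. Nothing at hand speaks to why removing the methyl moves the number as it does.

The compounds shown leave open whether the methoxy to hydroxy step has a similar size when phenoxy replaces dimethylamino, since this one pair rests on a single background. They also leave open how this oxygen position responds to a longer chain such as ethoxy, or to an amine in place of the hydroxy group, so no trend across substituents can yet be drawn there.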